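From Oxane to Difluorocyclohexane on the Amide Carbonyl

The compounds below may be only part of what the source reports. "The series", "measured", "known", "first", "only" and "open" are said of these compounds alone.

Compound 1 `CCc1ccccc1C(=O)Nc1c[nH]nc1C(=O)N[C@H]1CC[C@H](OC)CC1`: in an ADME assay on MRC5 cells (Homo sapiens) for inhibition, with a stated time of 72 h (on this read-out higher numbers stand for an effect only at larger amounts of compound and lower numbers for an effect already at smaller amounts), compound 1 gives 3400 nM.
Compound 2 `CO[C@H]1CC[C@H](NC(=O)c2n[nH]cc2NC(=O)C2CCOCC2)CC1`: in this assay compound 2 gives > 50000 nM, which is a limit of the assay and not a number.

For the measured compounds named here, the single measured step, an at least 14-fold higher number from compound 1 to compound 2 (1.16 log units; beyond the scatter), ends at the limit of > 50000 nM in this assay, at which 1 of the 2 values shown sits, so compound 2 stands at the upper edge of what was measured and its true number is not pinned down. Compound 3 `CO[C@H]1CC[C@H](NC(=O)c2n[nH]cc2NC(=O)C2CCC(F)(F)CC2)CC1` differs from compound 2 in one place: 4,4-difluorocyclohexyl in place of oxan-4-yl on a carbonyl carbon. Going by the values given here, no measured step covers this change; the one step recorded only shows where the oxan-4-yl group lands. Compound 3 is therefore expected to remain near that limit, with an estimated step of an at least 1.6-fold lower number from compound 2 to compound 3 (0.22 log units; that floor lies within the scatter) in this assay. The estimate for compound 3 is 30000 nM, between 8000 nM and 100000 nM.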

Compound 3, half-maximal effective concentration: > 50000 nM
Compound 3: no number, only a limit (the forecaster's own chance of this, stated with the estimate: 55%); middle value at least 1.6-fold (0.22 log units) away from the limit.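

In this assay compound 3 gives > 50000 nM, which is a limit of the assay and not a number. On this carbonyl carbon, 4,4-difluorocyclohexyl in place of 2-ethylphenyl gives an at least 14-fold higher number from compound 1 to compound 3 (1.16 log units; beyond the scatter), so a six-membered non-aromatic ring of carbon only lands at the same limit as oxan-4-yl. The step between compound 2 and compound 3 cannot be read, and the two compounds can only be placed together: the limit of > 50000 nM in this assay, at which 2 of the 3 values shown sit.

As far as these compounds go, how far apart compound 2 and compound 3 truly lie remains open. So does whether a plain phenyl or a piperidin-4-yl amine on this carbonyl carbon would bring the number back down.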